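Swapping the formylphenyl arm for a fluorophenyl one

The compounds below may be only part of what the source reports. "The series", "measured", "known", "first", "only" and "open" are said of these compounds alone.

Measured compounds:
compound 1 `Brc1cn2ccnc2c(-c2ccc3ncn(C4CCCCC4)c3c2)n1` — 10.2%
compound 2 `O=Cc1ccc(-c2cn3ccnc3c(-c3ccc4ncn(C5CCCCC5)c4c3)n2)cc1` — 54.5%
compound 3 `CC(=O)c1ccc(-c2cn3ccnc3c(-c3ccc4ncn(C5CCCCC5)c4c3)n2)cc1` — 8.6%

In a functional assay on NCI-H23 cells (Homo sapiens) for inhibition, read by sulforhodamine B assay, with a stated time of 48 h, tested at 10 uM (a lower number here means less inhibition, a higher number more inhibition at the concentration tested (going by the name of the read-out)), compound 2 stands highest of the three numbers. The step of a number 44.3 percentage points higher from compound 1 to compound 2 (beyond the scatter) is large, and so is a number 45.9 percentage points lower from compound 2 to compound 3 (beyond the scatter), whereas a number 1.6 percentage points lower from compound 1 to compound 3 (within the scatter) leaves compound 1 and compound 3 within the scatter of each other. Compound 4 `Fc1ccccc1-c1cn2ccnc2c(-c2ccc3ncn(C4CCCCC4)c3c2)n1` is not yet measured; it differs from compound 2 by 2-fluorophenyl in place of 4-formylphenyl on an aromatic carbon. Among the measured compounds shown here, two measured steps bear on this change: the gain with a number 44.3 percentage points higher from compound 1 to compound 2 (beyond the scatter) arrived together with the 4-formylphenyl group, and that gain vanished with a number 45.9 percentage points lower from compound 2 to compound 3 (beyond the scatter), where only the carbonyl carbon was altered. For the measured compounds named here, no measured compound carries a 2-fluorophenyl group, so there is no direct precedent for it. Since the high number of compound 2 was tied to the 4-formylphenyl group that now leaves, a large downward step is expected, a number 39.5 percentage points lower from compound 2 to compound 4 (beyond the scatter), toward the level of compound 1 and compound 3. Compound 4 is therefore estimated at 15%, with a range from 0% to 40%.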

Compound 4, a percentage reported as inhibition, at one concentration (the size of the read-out at that concentration, not a potency): 4.16%
Compound 4: the middle estimate sits 10.8 percentage points above what was measured, and the stated range covers the measured number.
By their numbers in this assay, from the lowest: compounds 4, 3 and 1 (each within the scatter of the next); then compound 2.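

In this assay, putting 2-fluorophenyl in place of 4-formylphenyl on this aromatic carbon gives a number 50.3 percentage points lower from compound 2 to compound 4 (beyond the scatter), which shows that the high number does not carry over to an aryl group without a carbonyl. The other two steps, a number 6 percentage points lower from compound 1 to compound 4 (within the scatter) and a number 4.4 percentage points lower from compound 3 to compound 4 (within the scatter), place the 2-fluorophenyl compound level with the bromo and 4-acetylphenyl compounds, so a phenyl ring at this position does not by itself raise the number, and among the compounds shown only the 4-formylphenyl compound stands apart. Nothing available here explains what sets that group apart.

Going by these compounds, it remains open whether a hydroxymethyl, a nitrile or a carboxylic acid in place of the formyl group would keep any of the high number. On these data alone, it is also open whether 4-fluorophenyl would read like 2-fluorophenyl.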